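The source may hold more compounds than are shown below. What is called first, only, known or untested is meant among the compounds shown, and "the series" means these compounds.

Three compounds sharing a fused two-ring core have been examined in a functional assay on the whole organism (strain Sprague-Dawley) for inhibition, with Rattus norvegicus as the target; on this read-out lower numbers stand for an effect already at smaller amounts and higher numbers for an effect only at larger amounts of compound. Compound 3 `Cc1ccc2cc(C(=O)O)cnc2c1C` carries a carboxy group and in this assay gives 50 mg/kg. Compound 1 `Cc1cc([N+](=O)[O-])c2cc(-c3nn[nH]n3)cnc2c1C`, which bears a tetrazolyl group together with a nitro group, gives 25 mg/kg. Compound 3 thus stands as the higher of the two numbers shown, its nearest neighbour being compound 1, although that gap lies within the scatter. Compound 2 `Cc1cccc2cc(C(=O)O)cnc12` reaches in this assay only the limit > 25 mg/kg, which is a limit of the assay and not a number. The step that the limit leaves unreadable from compound 2 to compound 3, methyl in place of hydrogen on an aromatic carbon, is left unreadable by that limit (the limit of > 25 mg/kg in this assay, at which 1 of the 3 values shown sits).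

The compound not yet measured is compound 4 `Cc1ccc2cc(-c3nn[nH]n3)cnc2c1C`, which differs from compound 3 by 2H-tetrazol-5-yl in place of carboxy on an aromatic carbon. For the measured compounds named here, no measured step isolates this exchange: compound 1 and compound 3 differ by it and by the nitro group at once, and their values sit within the scatter of each other. Going by the values given here, nothing among the measured steps therefore argues for a change beyond the scatter, and the step of a 1.4-fold lower number from compound 3 to compound 4 (0.15 log units; within the scatter) is expected to be small. For compound 4 the estimated value is 35 mg/kg, with a range from 12 mg/kg to 75 mg/kg.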

Compound 4, minimum effective dose: 25 mg/kg
Compound 4: middle estimate off by 1.4-fold (0.15 log units), on the high side, within the range that was stated.
By their numbers in this assay, from the lowest: compounds 1, 4 and 3 (each within the scatter of the next).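

For the compounds shown here, compound 4 allows the exchange of carboxy for 2H-tetrazol-5-yl, on the aromatic carbon two atoms from the ring nitrogen, to be read on its own for the first time: this assay shows a 2.0-fold lower number from compound 3 to compound 4 (0.30 log units; within the scatter) for this change. It also isolates the nitro group, since hydrogen in its place gives no change at the digits printed from compound 1 to compound 4 (within the scatter) in the same read-out. Compound 1 and compound 3 differ in both places at once and could not show this, whereas these two steps, each within the scatter, show that the read-out separates neither carboxy from 2H-tetrazol-5-yl at this position nor nitro from hydrogen on this shared core.

The compounds shown leave open whether another group at this position, such as an amine or a methyl ester, would give a number beyond the scatter from those of compound 3 and compound 4. The data shown offer no explanation for why either exchange stays within the scatter.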